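A few compounds are considered here, and "the series" means these few. Any claim that something is new, unique, unknown or untested is made for them only; others in the source may bear on it.

Series notes. Compound 1 `O=c1c(SC(=S)N2CCCC2)coc2ccc(Cl)cc12` is the parent of the step under study. In a functional assay on SW480 cells (Homo sapiens) for antiproliferative activity, read by MTT assay, with a stated time of 72 h (on this read-out higher numbers stand for weaker inhibition and lower numbers for stronger inhibition), compound 1 gives > 25000 nM, which is a limit of the assay and not a number. Compound 1 therefore sits at the limit of > 25000 nM in this assay, at which 1 of the 3 values shown sits. Compound 2 `COc1ccc2oc(CSC(=S)N(C(C)C)C(C)C)cc(=O)c2c1` gives 7200 nM in this assay. Compound 3 `Cc1ccc2c(=O)c(CSC(=S)N3CCCC3)coc2c1` gives 5900 nM in this assay. Within the data shown here, compounds 2 and 3 differ from compound 1 in more than one place, so no single step connects them; their values show only that a numerical read-out is reached in this assay. Compound 4 `O=c1c(SC(=S)N2CCCCC2)coc2ccc(Cl)cc12` is not yet measured; it differs from compound 1 by piperidin-1-yl in place of pyrrolidin-1-yl on a thiocarbonyl carbon. Among the measured compounds shown here, no measured step of this kind exists among the compounds. The step is expected to be a step that the limit leaves unreadable from compound 1 to compound 4, none beyond the scatter. Compound 4 is estimated at 30000 nM, with a range from 10000 nM to 100000 nM, most probably reported again only as a limit.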

Compound 4, half-maximal inhibitory concentration: > 25000 nM
Compound 4: no number, only a limit (the forecaster's own chance of this, stated with the estimate: 70%); the middle value does not contradict the limit.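

No step can be read between compound 1 and compound 4, because both values are limits and not numbers: the limit of > 25000 nM in this assay, at which 2 of the 4 values shown sit.

The compounds shown leave open whether piperidin-1-yl and pyrrolidin-1-yl on a thiocarbonyl carbon differ at all on the core of compound 1.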